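Hydroxy for nitro in a small lipophilicity series

This account rests on a few compounds, and the source may have more. Where it says the series, first, only, none or still open, it means among the compounds named here.

- compound 1 `O=C(N/N=C/c1ccc2no[n+]([O-])c2c1)c1ccccc1O` gives 1.3
- compound 2 `NC(=O)c1c(COc2cccc(/C=N/NC(=O)c3ccncc3)c2)no[n+]1[O-]` gives 1.3
- compound 3 `O=C(N/N=C/c1ccc2no[n+]([O-])c2c1)c1ccc([N+](=O)[O-])cc1` gives 0.9

In a physicochemical assay for lipophilicity, read by HPLC, measured as octanol-water partition (a higher number here means a more lipophilic compound, a lower number a more polar compound), compound 3 stands lowest of the three, with compound 1 and compound 2 both above it beyond the scatter. Compound 4 `O=C(N/N=C/c1ccc2no[n+]([O-])c2c1)c1ccc(O)cc1` comes from compound 3 by one change, hydroxy in place of nitro on an aromatic carbon (hydroxy in place of nitro on an aromatic carbon, para to a large group). Going by the values given here, no measured single-change step is available as a guide. Compound 1, which also carries a hydroxy, gives 1.3 and that is the only nearby reference. No step beyond the scatter is expected in this assay here. An estimated a number 0.10 log units lower from compound 3 to compound 4 (within the scatter) is the working expectation. For compound 4 the estimated value is 0.8 (expected range 0.3 to 1.3).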

Compound 4, partition coefficient: 1.2
Estimate against measurement, compound 4: 0.40 log units below; the measured number falls inside the stated range.
By their numbers in this assay, from the lowest: compounds 3, 4, 1 and 2 (each within the scatter of the next, the first and the last beyond it).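

In this assay, going by these compounds alone, hydroxy in place of nitro on this aromatic carbon, para to a large group, gives a number 0.30 log units higher from compound 3 to compound 4 (within the scatter) as the first single-change step at this position. 4-hydroxyphenyl in place of 2-hydroxyphenyl on a carbonyl carbon gives a number 0.10 log units lower from compound 1 to compound 4 (within the scatter) and so does not separate these two compounds. Nothing available bears on the reason for either step. Open, as far as these compounds go, is whether an amine or a carboxylic acid on this aromatic carbon would give a step beyond the scatter from compound 3.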